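Triazole for imidazole on the thioether arm

The source may hold more compounds than are shown below. What is called first, only, known or untested is meant among the compounds shown, and "the series" means these compounds.

The two measured compounds share a core and differ only in the group on the sulfur-bound chain. Compound 1 `C=CCOc1ccc(-c2c(C#N)c(N)nc(SCC(N)=O)c2C#N)cc1` carries an amide-bearing chain, and in an assay on CHO cells for displacement of a labelled ligand from adenosine receptor A1 (Homo sapiens), read by scintillation counting, with a stated time of 90 min (on this read-out lower numbers stand for stronger inhibition and higher numbers for weaker inhibition), compound 1 gives 323 nM. Compound 2 `N#Cc1c(N)nc(SCc2ncc[nH]2)c(C#N)c1-c1ccc(OCC2CC2)cc1` carries the (1H-imidazol-2-yl)methyl chain, and in this assay compound 2 gives 235 nM. The two values lie within the usual scatter of each other, so neither can be placed above or below the other. Compound 3 `N#Cc1c(N)nc(SCc2ncn[nH]2)c(C#N)c1-c1ccc(OCC2CC2)cc1` is not yet measured; it differs from compound 2 by 1H-1,2,4-triazol-5-yl in place of 1H-imidazol-2-yl on a saturated chain carbon bound to a sulfur. For the measured compounds named here, no measured pair shows this change, so there is no step to lean on. Given that compound 2 gives 235 nM, the expectation is that compound 3 stays close to it, with a step of a 1.3-fold higher number from compound 2 to compound 3 (0.11 log units; within the scatter) not beyond the scatter in either direction. Compound 3 is therefore estimated at 300 nM, with a range from 120 nM to 800 nM.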

Compound 3, inhibition constant: 338 nM
For compound 3 the middle estimate is 1.1-fold (0.05 log units) below the measured one; low and high end bracket the measured number.
By their numbers in this assay, from the lowest: compounds 2, 1 and 3 (each within the scatter of the next).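

For the compounds shown here, this is the first step that can be read at this position. In this assay, 1H-1,2,4-triazol-5-yl in place of 1H-imidazol-2-yl on a saturated chain carbon bound to a sulfur gives a 1.4-fold higher number from compound 2 to compound 3 (0.16 log units; within the scatter), so the read-out does not separate the two rings, even though the entering ring has 3 hetero atoms and 2 hydrogen-bond acceptors where the leaving ring has 2 and 1. No supporting evidence bears on why the two rings read alike.

The compounds shown leave open whether a pyridin-2-yl ring, a carboxylic acid or an amine on the same saturated chain carbon would also stay within the scatter of compound 2. They also leave open whether the same ring exchange would read alike with a group other than the cyclopropylmethyl ether on the shared core.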